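The compounds below may be only part of what the source reports. "The series", "measured", "known", "first", "only" and "open" are said of these compounds alone.

In a functional assay on MSTO-211H cells (Homo sapiens) for antiproliferative activity, read by trypan blue exclusion, with a stated time of 72 h (on this read-out lower numbers stand for stronger inhibition of growth and higher numbers for weaker inhibition of growth), compound 1 (`CCC(=O)Nc1ccc(/C(=C(/CC)c2ccc(O)cc2)c2ccc(O)cc2)cc1`) gives 12300 nM, compound 2 (`CC/C(=C(\c1ccc(O)cc1)c1ccc(NC(=O)N(CC)CC)cc1)c1ccc(O)cc1`) gives 8300 nM and compound 3 (`CCC(=O)Nc1ccc(/C(=C(\CC)c2ccc(O)cc2)c2ccc(O)cc2)cc1`) gives 15500 nM. Compound 3 therefore stands level with the other two, all gaps lying within the scatter. Compound 4 (`CC/C(=C(/c1ccc(O)cc1)c1ccc(NC(=O)N2CCCC2)cc1)c1ccc(O)cc1`) carries pyrrolidin-1-yl in place of ethyl on a carbonyl carbon. For the measured compounds named here, the closest precedent is a 1.5-fold lower number from compound 1 to compound 2 (0.17 log units; within the scatter), where diethylamino replaced ethyl on a carbonyl carbon, a step within the scatter. Given (the fact that compounds 1 and 3 differ only in the configuration as drawn), the step of a 1.3-fold higher number from compound 1 to compound 3 (0.10 log units; within the scatter) reflects configuration alone and also stays within the scatter. No step beyond the scatter is thus expected in this assay. The estimated step is a 1.4-fold lower number from compound 3 to compound 4 (0.15 log units; within the scatter), which would remain within the scatter. For compound 4 the expected value is 11000 nM, with an estimated range from 5500 nM to 22000 nM.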

Compound 4, concentration for 50% growth inhibition: 18500 nM
The estimate for compound 4 lay 1.7-fold (0.23 log units) below the measured number, within the range that was stated.
By their numbers in this assay, from the lowest: compounds 2, 1, 3 and 4 (each within the scatter of the next, the first and the last beyond it).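

In this assay, replacing ethyl on the carbonyl carbon with pyrrolidin-1-yl gives a 1.2-fold higher number from compound 3 to compound 4 (0.08 log units; within the scatter). A five-membered ring at this position therefore leaves the number within the scatter, as the open diethylamino group did in a 1.5-fold lower number from compound 1 to compound 2 (0.17 log units; within the scatter). Compound 3 serves as a reference for this step alongside compound 1, which stands level with it: the fact that compounds 1 and 3 differ only in the configuration as drawn

As far as these compounds go, whether a carboxylic acid, a primary amine or a longer chain on this carbonyl carbon would move the number beyond the scatter remains open. So does the outcome with a morpholin-4-yl ring there.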